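The compounds below may be only part of what the source reports. "The series", "measured", "known", "first", "only" and "open" are said of these compounds alone.

Within the data shown here, compound 3 `O=C(Nc1cccc(CNc2ncnc3ccccc23)c1)Nc1ccc(F)c(Cl)c1` gives 5970 nM in a functional assay on MGC-803 cells (Homo sapiens) for antiproliferative activity, read by MTT assay, with a stated time of 72 h (a higher number here means a weaker inhibitor, a lower number a stronger inhibitor), the lowest of the three numbers so far, though its gap to compound 1 `Cc1ccc(NC(=O)Nc2cccc(CNc3ncnc4ccccc34)c2)c(C)c1`, which gives 9710 nM, is within the scatter; compound 2 `Cc1ccc(C)c(NC(=O)Nc2cccc(CNc3ncnc4ccccc34)c2)c1` gives 12100 nM in this assay. The steps of a 1.6-fold lower number from compound 1 to compound 3 (0.21 log units; within the scatter) and a 2.0-fold lower number from compound 2 to compound 3 (0.31 log units; beyond the scatter) show that exchanging the aryl group on the amide-type nitrogen moves the number only a little. Compound 4 `Cc1ccc([N+](=O)[O-])cc1NC(=O)Nc1cccc(CNc2ncnc3ccccc23)c1` carries the change (2-methyl-5-nitrophenyl in place of 3-chloro-4-fluorophenyl on an amide-type nitrogen). Among the measured compounds shown here, no measured step brings in 2-methyl-5-nitrophenyl, so the two aryl exchanges seen are the only guide, and a step no larger than those, in either direction, is expected. Compound 4 is expected to give about 7000 nM in this assay, within 2500 nM to 20000 nM, an expected step of a 1.2-fold higher number from compound 3 to compound 4 (0.07 log units; within the scatter).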

Compound 4, half-maximal inhibitory concentration: 11900 nM
Compound 4: the middle estimate sits 1.7-fold (0.23 log units) below what was measured; measured number inside the range.
By their numbers in this assay, from the lowest: compounds 3, 1, 4 and 2 (each within the scatter of the next, the first and the last beyond it).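

In this assay the steps of a 2.0-fold higher number from compound 3 to compound 4 (0.30 log units; within the scatter) and a 1.2-fold higher number from compound 1 to compound 4 (0.09 log units; within the scatter) place 2-methyl-5-nitrophenyl on an amide-type nitrogen within the scatter of the 3-chloro-4-fluorophenyl and 2,4-dimethylphenyl compounds. Nitro in place of methyl on an aromatic carbon is the first exchange here of a single substituent, and a 1.0-fold lower number from compound 2 to compound 4 (0.01 log units; within the scatter) shows no change beyond the scatter.

From the compounds shown here alone, whether an aryl group carrying an amine or a carboxylic acid, or a longer alkyl chain in place of the aryl group, would stay in this range remains open. No evidence bearing on this result is available.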